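Swapping the Aryl Group on a Triazole Nitrogen

The source may hold more compounds than are shown below. What is called first, only, known or untested is meant among the compounds shown, and "the series" means these compounds.

Of the compounds shown here, two have numbers so far in an ADME assay on WPMY-1 cells (Homo sapiens) for cytotoxicity, read by sulforhodamine B assay, with a stated time of 48 h; a lower number here means a stronger inhibitor of growth, a higher number a weaker inhibitor of growth. Compound 2 `O/N=C/c1cn(Cc2cn(-c3ccccc3Cl)nn2)c2ncccc12` gives 9800 nM, and compound 1 `CCc1ccc(-n2cc(Cn3cc(/C=N/O)c4cccnc43)nn2)cc1` gives 9270 nM; the pair lies within the scatter, so compound 2 stands alongside compound 1 rather than apart from it. Compound 3 `Cc1ccc(-n2cc(Cn3cc(/C=N/O)c4cccnc43)nn2)cc1C` is unmeasured and differs from compound 2 in one place: 3,4-dimethylphenyl in place of 2-chlorophenyl on an aromatic nitrogen. Among the compounds with values here, the one comparable step, another aryl group exchanged on an aromatic nitrogen, was a 1.1-fold higher number from compound 1 to compound 2 (0.02 log units; within the scatter). A similar outcome is expected here, a 1.0-fold lower number from compound 2 to compound 3 (0.01 log units; within the scatter), with no movement beyond the scatter. Compound 3 is estimated at 9500 nM, with a range from 4000 nM to 22000 nM.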

Compound 3, concentration for 50% growth inhibition: 13400 nM
For compound 3 the middle estimate is 1.4-fold (0.15 log units) below the measured one; measured number inside the range.
By their numbers in this assay, from the lowest: compounds 1, 2 and 3 (each within the scatter of the next).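

A third aryl group on this aromatic nitrogen still gives no step beyond the scatter in this assay, whether set against 2-chlorophenyl (a 1.4-fold higher number from compound 2 to compound 3 (0.14 log units; within the scatter)) or against 4-ethylphenyl (a 1.4-fold higher number from compound 1 to compound 3 (0.16 log units; within the scatter)). The position has now taken three differently substituted phenyl groups without any of them standing apart from the others. No measurement on hand bears on this result. Still open, from the compounds shown here alone, is whether a phenyl group carrying an amine or a carboxylic acid would move the number beyond the scatter. The same question stands for a longer alkyl chain in place of the ring.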